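Swapping the benzothiophene arm of a spiro-lactone core

The compounds below may be only part of what the source reports. "The series", "measured", "known", "first", "only" and "open" are said of these compounds alone.

Compound 1 `O=C1C=CC2(C=C1)OC(=O)C(c1cc3ccccc3s1)=C2c1ccccc1`: 32900 nM
Compound 2 `O=C1C=CC2(C=C1)OC(=O)C(c1cc3ccccc3o1)=C2c1ccccc1`: 21200 nM
Compound 3 `O=C1C=CC2(C=C1)OC(=O)C(c1ccc(CO)cc1)=C2c1ccccc1`: 8850 nM

In a functional assay on MDA-MB-231 cells (Homo sapiens) for antiproliferative activity, read by MTT assay, with a stated time of 48 h (on this read-out higher numbers stand for weaker inhibition and lower numbers for stronger inhibition), compound 1 gives 32900 nM and stands at the top of the three numbers. Its nearest neighbour is compound 2; a 1.6-fold lower number from compound 1 to compound 2 (0.19 log units; within the scatter). The furthest is compound 3; a 3.7-fold lower number from compound 1 to compound 3 (0.57 log units; beyond the scatter), and a 2.4-fold lower number from compound 2 to compound 3 (0.38 log units; beyond the scatter).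

Compound 4 `COc1ccc(F)cc1C1=C(c2ccccc2)C2(C=CC(=O)C=C2)OC1=O` differs from compound 1 in one place: 5-fluoro-2-methoxyphenyl in place of 1-benzothiophen-2-yl on a double-bonded ring carbon. Among the compounds with values here, the step that bears most directly on this change is the one from compound 1 to compound 3, where a six-membered carbon ring also took the place of the bicyclic group and the number fell modestly. The step from compound 1 to compound 2 shows that exchanging one bicyclic group for another stayed within the scatter. Compound 4 is therefore expected to sit below compound 1 in this assay, with a 2.2-fold lower number from compound 1 to compound 4 (0.34 log units; beyond the scatter) as the expected step. The estimated value for compound 4 is 15000 nM, with a range from 5000 nM to 45000 nM.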

Compound 4, half-maximal inhibitory concentration: 10000 nM
Estimate against measurement, compound 4: 1.5-fold (0.18 log units) above; low and high end bracket the measured number.
By their numbers in this assay, from the lowest: compounds 3 and 4 (each within the scatter of the next); then compounds 2 and 1 (each within the scatter of the next).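

In this assay, a six-membered carbon ring without a hydroxymethyl group also gives a step beyond the scatter when it replaces either bicyclic group at this double-bonded ring carbon (a 3.3-fold lower number from compound 1 to compound 4 (0.52 log units; beyond the scatter); a 2.1-fold lower number from compound 2 to compound 4 (0.33 log units; beyond the scatter)). The 5-fluoro-2-methoxyphenyl and 4-(hydroxymethyl)phenyl groups cannot be told apart here (a 1.1-fold higher number from compound 3 to compound 4 (0.05 log units; within the scatter)), so among these compounds the lower numbers do not depend on the hydroxymethyl group. Nothing available explains these differences.

The compounds shown leave open whether an amine, a carboxylic acid or a longer chain on this carbon would give a similar number, and whether the fluoro or the methoxy group alone would do so. Going by these compounds, the phenyl group on the neighbouring ring atom is the same in all four compounds, so the effect of changing it also remains open.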